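A few compounds are considered here, and "the series" means these few. Any claim that something is new, unique, unknown or untested is made for them only; others in the source may bear on it.

Measured compounds:
- Compound 1, `COC(=O)N(C)C(C)C#CCN1CCCC1`: in a functional assay on the whole organism for antagonist activity, with Mus musculus as the target (a higher number here means that more compound is needed for the effect, a lower number that less compound is needed), compound 1 gives > 100 mg/kg, a limit of the assay.
- Compound 2, `COC(=O)N(C)C(C)C#CCn1ccnc1`: in this assay compound 2 gives > 100 mg/kg, a limit of the assay.
- Compound 3, `CN(C)C(=O)N(C)CC#CCN1CCCC1`: in this assay compound 3 gives > 10 mg/kg, a limit of the assay.

The change from compound 1 to compound 2 is 1H-imidazol-1-yl in place of pyrrolidin-1-yl on a saturated chain carbon bound to a triple-bonded carbon. The step it made, a step that the two limits leave unreadable from compound 1 to compound 2, cannot be read, as both compounds sit at the limit of > 100 mg/kg in this assay, at which 2 of the 3 values shown sit. The same change, at the same place, is to be made from compound 3 to compound 4, `CN(C)C(=O)N(C)CC#CCn1ccnc1`, which is not yet measured: 1H-imidazol-1-yl in place of pyrrolidin-1-yl on a saturated chain carbon bound to a triple-bonded carbon. The cores of compound 1 and compound 3 differ, and the difference between the two cores is not broken down here. Compound 3 stands at the limit of > 10 mg/kg in this assay, at which 1 of the 3 values shown sits.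

Compound 4 is expected to give 30 mg/kg. For compound 4 the expected range runs from 10 mg/kg to 150 mg/kg. The expected step is a step that the limit leaves unreadable from compound 3 to compound 4, to be compared with the unreadable measured one. This rests on compound 3 sitting at the limit of > 10 mg/kg in this assay, at which 1 of the 3 values shown sits, and on the same change leaving compound 1 and compound 2 both at the limit of > 100 mg/kg in this assay, at which 2 of the 3 values shown sit; a reported limit rather than a number is the likelier outcome for compound 4.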

Compound 4, dose for half-maximal effect: > 100 mg/kg
Compound 4: only a limit was reported; the forecaster's own chance of this, stated with the estimate: 85%; at least 3.3-fold (0.52 log units) between middle value and limit.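

Compound 3 and compound 4 both stand at limits of the assay in this assay, and the step between them cannot be read. Compound 4 gives > 100 mg/kg, which is a limit. The compounds shown leave open whether 1H-imidazol-1-yl in place of pyrrolidin-1-yl changes the dose for half-maximal effect at all: neither compound 1 with compound 2 nor compound 3 with compound 4 gives a number.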